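The source may report more compounds than this note shows. Statements on the series, on what has been measured and on what is new or still open speak of the compounds shown alone.

Working notes on the series. Two compounds have numbers in a functional assay on MKN-45 cells (Homo sapiens) for cytotoxicity, read by MTT assay, with a stated time of 72 h; a higher number here means a weaker inhibitor, a lower number a stronger inhibitor. Compound 1 `CN(C)CCn1cnnc1-c1cc(Oc2ccc(NC(=O)N/N=C/c3ccccc3)cc2F)ccn1` gives 2730 nM. Compound 2 `CN(C)CCn1cnnc1-c1cc(Oc2ccc(NC(=O)N/N=C/c3c(O)ccc4ccccc34)cc2F)ccn1` gives 2020 nM. Among the compounds with values here, the single step between them, a 1.4-fold lower number from compound 1 to compound 2 (0.13 log units; within the scatter), is within the scatter, so compound 2 stands next to compound 1 and the two are not distinguished by these numbers. Compound 3 `Cc1cc(/C=N/NC(=O)Nc2ccc(Oc3ccnc(-c4nncn4CCN(C)C)c3)c(F)c2)cc(C)c1O` has not been measured. It differs from compound 2 at one place: 4-hydroxy-3,5-dimethylphenyl in place of 2-hydroxynaphthalen-1-yl on a carbon with a double bond to nitrogen. Within the data shown here, the only measured step that touches this carbon is the one from compound 1 to compound 2, and that exchange of one group for another on the same carbon stayed within the scatter in this assay. The expected step is therefore a 1.1-fold higher number from compound 2 to compound 3 (0.06 log units; within the scatter), with no movement beyond the scatter anticipated in either direction. Compound 3 is estimated at 2300 nM, with an expected range from 900 nM to 6000 nM.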

Compound 3, half-maximal inhibitory concentration: 1510 nM
Compound 3: the middle estimate sits 1.5-fold (0.18 log units) above what was measured, and the stated range covers the measured number.
By their numbers in this assay, from the lowest: compounds 3, 2 and 1 (each within the scatter of the next).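

With compound 3, a third group on the carbon with a double bond to nitrogen stays within the scatter in this assay: the exchange of 2-hydroxynaphthalen-1-yl for 4-hydroxy-3,5-dimethylphenyl gives a 1.3-fold lower number from compound 2 to compound 3 (0.13 log units; within the scatter), and the exchange of phenyl for 4-hydroxy-3,5-dimethylphenyl gives a 1.8-fold lower number from compound 1 to compound 3 (0.26 log units; within the scatter). The position now carries three different groups, with one or two six-membered aromatic rings, and the numbers do not distinguish any of the three compounds from the others. Nothing available bears on the reason for these numbers.

From the compounds shown here alone, whether an amine or a carboxylic acid on the phenyl ring, or a longer chain in its place, would move the number beyond the scatter remains open. Going by these compounds, the rest of the shared core is identical in all three compounds, so the effect of changes there is also open.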